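The compounds below may be only part of what the source reports. "The series", "measured", "known", "first", "only" and "open" are said of these compounds alone.

Measured so far in an ADME assay on MT4 cells (Homo sapiens) for cytotoxicity, read by MTT assay, with a stated time of 5 days; a higher number here means that more compound is tolerated, a lower number that less compound is tolerated:
- compound 1 `COc1cc2nc([S+]([O-])CC(=O)Nc3ccccc3[N+](=O)[O-])nc(Nc3c(Cl)cc(/C=C/C#N)cc3Cl)c2cc1OC`: > 199000 nM
- compound 2 `COc1cc2nc([S+]([O-])CC(=O)Nc3cccc([N+](=O)[O-])c3)nc(Nc3c(Cl)cc(/C=C/C#N)cc3Cl)c2cc1OC`: >= 83200 nM
- compound 3 `COc1cc2nc([S+]([O-])CC(=O)Nc3ccccc3C(F)(F)F)nc(Nc3c(Cl)cc(/C=C/C#N)cc3Cl)c2cc1OC`: > 192000 nM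

Compound 3 stands at > 192000 nM, which is a limit and not a number. Compound 1 gives > 199000 nM, also a limit. Compound 2 gives >= 83200 nM, again a limit. No order can be read among the three.

Compound 4 `COc1cc2nc([S+]([O-])CC(=O)Nc3cccc(C(F)(F)F)c3)nc(Nc3c(Cl)cc(/C=C/C#N)cc3Cl)c2cc1OC` differs from compound 3 by 3-(trifluoromethyl)phenyl in place of 2-(trifluoromethyl)phenyl on an amide-type nitrogen. Among the measured compounds shown here, the closest precedent is the nitro pair, with 3-nitrophenyl in place of 2-nitrophenyl, but a step that the two limits leave unreadable from compound 1 to compound 2 gives no size. The other two measured steps, a step that the two limits leave unreadable from compound 1 to compound 3 and a step that the two limits leave unreadable from compound 2 to compound 3, give none either. With no readable step to draw on, no change beyond the scatter is expected in this assay. The expected step is an at least 1.1-fold lower number from compound 3 to compound 4 (0.05 log units; that floor lies within the scatter). Another limit is the likely report. For compound 4 the estimated value is 170000 nM, with an expected range of 80000 nM to 300000 nM.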

Compound 4, half-maximal cytotoxic concentration: 21800 nM
The estimate for compound 4 lay 7.8-fold (0.89 log units) above the measured number; measured number outside the range, below it.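

In this assay, 3-(trifluoromethyl)phenyl in place of 2-(trifluoromethyl)phenyl on the amide-type nitrogen gives an at least 8.8-fold lower number from compound 3 to compound 4 (0.94 log units; beyond the scatter), so a change that leaves the atoms the same is enough to move this assay's read-out beyond the scatter. Against the nitro compounds, the series shows an at least 3.8-fold lower number from compound 2 to compound 4 (0.58 log units; beyond the scatter) and an at least 9.1-fold lower number from compound 1 to compound 4 (0.96 log units; beyond the scatter). Compound 4 alone of the four gives a number, the steps among compounds 1, 2 and 3 cannot be read, and each step here is only a floor set by a limit, such as the one for compound 3: the limit of > 192000 nM in this assay, at which 1 of the 4 values shown sits.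

As far as these compounds go, the full size of each step stays open. Also open, from the compounds shown here alone, is how an amine or a carboxylic acid in place of trifluoromethyl on this aromatic ring would read in this assay.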